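Aminopropyl extension on the ester chain of compound 1

This account rests on a few compounds, and the source may have more. Where it says the series, first, only, none or still open, it means among the compounds named here.

Of the compounds shown here, three on a shared core have been measured. In a functional assay on the whole organism (Tail, strain ICR) with Mus musculus as the target, in the tail flick test, with a stated time of 120 min, at a dose of 25 umol/kg by the oral route (on this read-out lower numbers stand for a weaker effect and higher numbers for a stronger effect at the one dose given), compound 1 `C[C@H](NC(=O)CN(c1nc(Cl)nc2[nH]cnc12)C1CC1)C(=O)OCc1ccccc1` gives 36.1%, the second highest of the three numbers. Within the data shown here, compound 2 `O=C(CN(c1nc(Cl)nc2[nH]cnc12)C1CC1)N[C@@H](CO)C(=O)O` gives 39% in this assay, a number within the scatter of the one for compound 1, so no order between these two can be read. Compound 3 `CC[C@H](C)[C@H](NC(=O)CN(c1ncnc2c1ncn2C1CCCCO1)C1CC1)C(=O)OCc1ccccc1` gives 20.4%, a number beyond the scatter below that of compound 1. Among the measured compounds shown here, no two of the measured compounds differ in a single place, so no single structural step has a measured size.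

Compound 4 `NCCCC[C@H](NC(=O)CN(c1nc(Cl)nc2[nH]cnc12)C1CC1)C(=O)OCc1ccccc1` is not yet measured. It differs from compound 1 in one place: 3-aminopropyl in place of hydrogen on a saturated chain carbon, two bonds along the chain from an amide-type nitrogen and a carbonyl carbon. For the measured compounds named here, nothing measured so far tells how a change of this kind moves the read-out, as the other measured compounds carry several changes at once. The step of a number 1.1 percentage points lower from compound 1 to compound 4 (within the scatter) is expected to be small, none beyond the scatter in either direction. Compound 4 is estimated at 35% in this assay, with a range from 20% to 50%.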

Compound 4, a percentage reported as activity, at one dose (the size of the read-out at that dose, not a potency): 16.8%
Compound 4: the middle estimate sits 18.2 percentage points above what was measured; measured number outside the range, below it.
By their numbers in this assay, from the lowest: compounds 4 and 3 (each within the scatter of the next); then compounds 1 and 2 (each within the scatter of the next).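

Among these compounds, compound 4 gives the first single-place step: in this assay, 3-aminopropyl in place of hydrogen on a saturated chain carbon, two bonds along the chain from an amide-type nitrogen and a carbonyl carbon, gives a number 19.3 percentage points lower from compound 1 to compound 4 (beyond the scatter). Among the compounds shown here, the read-out at this one dose therefore responds to what stands at this chain position, which the earlier compounds, each differing from compound 1 in several places, could not show. Nothing at hand bears on what lies behind this step.

Going by these compounds, whether the step goes with the amine of the 3-aminopropyl or with the added chain itself stays open; an unsubstituted butyl chain or a carboxylic acid in the same place would separate the two. On these data alone, whether the same step holds with a shorter chain carrying an amine also remains unknown.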